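This account rests on a few compounds, and the source may have more. Where it says the series, first, only, none or still open, it means among the compounds named here.

The series rests on a shared core in which an ester is joined to the core through an oxygen-bearing methylene. Compound 1 `CC(=O)OCn1oc(=O)c2ccccc21` carries an acetyl group on that oxygen, and in a functional assay on L1210 cells (Mus musculus) for cytotoxicity (a lower number here means a stronger inhibitor, a higher number a weaker inhibitor), compound 1 gives 5.1 ug/mL. Among the numbers shown, compound 1 holds the only single value; one further entry for it carries no single number. Compound 2 `O=C(CCCCCI)OCn1oc(=O)c2ccccc21` carries a different ester group, and in this assay compound 2 gives 19 ug/mL; 43 ug/mL (2 entries). Within the data shown here, the spread of the several entries of compound 2 in this assay, 19 ug/mL; 43 ug/mL (2 entries) shows how far repeats of one compound can fall apart, and it serves as the only guide to how much weight a single number can bear. Among the measured compounds shown here, no pair of measured compounds differs in one place only, so no measured step is available.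

Compound 3 `CNC(=O)OCn1oc(=O)c2ccccc21` differs from compound 1 by methylamino in place of methyl on a carbonyl carbon. In this assay the step from compound 1 to compound 3 is expected to be small, a 1.6-fold higher number from compound 1 to compound 3 (0.20 log units; within the scatter), leaning if anywhere toward a weaker inhibitor, and not beyond the scatter. For compound 3 in this assay the estimate is 8 ug/mL, with a range from 2.5 ug/mL to 25 ug/mL.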

Compound 3, concentration for 50% inhibition: 3.5 ug/mL
For compound 3 the middle estimate is 2.3-fold (0.36 log units) above the measured one, within the range that was stated.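

With this result the series gains its first measured step, at a carbonyl carbon whose other neighbour is the oxygen of the ester link. In this assay, the exchange of methyl for methylamino, which turns acetyl into methylcarbamoyl and adds a nitrogen and a hydrogen-bond donor, amounts to a 1.5-fold lower number from compound 1 to compound 3 (0.16 log units; within the scatter). The position therefore accepts this particular change without a step that can be told apart from the scatter, and no order can be set between the two compounds, a reading supported by how far repeats of a single compound lie apart in this series: the several entries of compound 2 in this assay, 19 ug/mL; 43 ug/mL (2 entries)

What the compounds shown leave open is whether this holds for anything larger or different on the same carbonyl carbon, such as a dimethylamino group, a longer alkylamino chain or a phenyl ring. A single step within the scatter also cannot say whether the methylamino group is neutral in general or only in the setting of compound 3, and a second group at this place would be needed to tell.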